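A few compounds are considered here, and "the series" means these few. Any claim that something is new, unique, unknown or untested is made for them only; others in the source may bear on it.

Measured so far in a functional assay on the whole organism for inhibition, with Echinochloa esculenta as the target; a higher number here means a weaker inhibitor, a lower number a stronger inhibitor:

- compound 1 `CC(C)Oc1cc(/N=c2\sc(=S)n3n2CCCC3)c(F)cc1Cl` gives 28.2 nM as its half-maximal inhibitory concentration
- compound 2 `S=c1n(-c2ccc(Br)cc2)c(=S)n2n1CCCC2` gives 66.1 nM as its half-maximal inhibitory concentration

Of these two, compound 1 has the lower number and is therefore the stronger inhibitor, and the gap between them lies beyond the usual scatter of repeated measurements.

Compound 3 `C#CCOc1cc(/N=c2\sc(=S)n3n2CCCC3)c(F)cc1Cl` has not yet been measured. It keeps the core of compound 1 and changes one group, with propargyl in place of isopropyl on an oxygen on an aromatic ring and nothing else altered.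

Among the compounds with values here, no measured pair here shows what this swap does, so the data offer no direct guide to its size or direction. The best starting point is compound 1 at 28.2 nM in this assay and no shift beyond the scatter is expected, in either direction. The expected change is a 1.1-fold lower number from compound 1 to compound 3 (0.05 log units; within the scatter) and would be too small to count as a real difference. For compound 3 the estimated value is 25 nM with an expected range from 8 nM to 80 nM in this measurement.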

Compound 3, half-maximal inhibitory concentration: 5.89 nM
Beside the measured number, compound 3's estimate is 4.2-fold (0.63 log units) above it; measured number below the stated range.
By their numbers in this assay, from the lowest: compound 3; then compound 1; then compound 2.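

The group on the oxygen clearly matters in this assay: with the rest of the molecule unchanged, propargyl in place of isopropyl gives a 4.8-fold lower number from compound 1 to compound 3 (0.68 log units; beyond the scatter). The earlier pair could not show this, as compound 1 and compound 2 differ in more than one place, whereas here both groups have three carbon atoms and neither has a ring, a hydrogen-bond donor, a hydrogen-bond acceptor or a net charge, so the counted difference is the triple bond that propargyl adds. Nothing available here explains why the number falls, so the reason for this step remains unknown.

A single step cannot tell whether the triple bond itself is what counts or whether other small groups on this oxygen would serve as well; an allyl group, with a double bond in place of the triple bond, and a longer chain such as butynyl would help separate these possibilities. As far as these compounds go, it also remains open whether the swap would give a step of similar size if the chlorine or fluorine on the aromatic ring were replaced by, for example, a methyl group.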